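Chloro for Methoxy on Two Oxazole Amide Cores

A few compounds are considered here, and "the series" means these few. Any claim that something is new, unique, unknown or untested is made for them only; others in the source may bear on it.

Compound 2, `COc1cccc(N2CCN(C(=O)c3oc(C)nc3-c3ccccc3)CC2)c1`, and compound 1, `Cc1nc(-c2ccccc2)c(C(=O)N2CCN(c3cccc(Cl)c3)CC2)o1`, share one core and differ only in one group. In a functional assay on HL-60 cells (Homo sapiens) for inhibition, read by MTT assay, with a stated time of 72 h (on this read-out lower numbers stand for stronger inhibition and higher numbers for weaker inhibition), compound 2 gives 34.8 nM, and compound 1 gives 39.2 nM in this assay. The change between them is chloro in place of methoxy on an aromatic carbon, and the step it made is a 1.1-fold higher number from compound 2 to compound 1 (0.05 log units; within the scatter), so the two values sit within the usual scatter of each other and nothing can be said about which is stronger.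

Compound 3, `COc1cccc(N2CCN(C(=O)c3oc(C(F)(F)F)nc3-c3ccc(F)cc3)CC2)c1`, carries a different core; the difference between the two cores is not broken down here. In this assay compound 3 was reported as "not active" (no number reported), with no single number given. Compound 4, `O=C(c1oc(C(F)(F)F)nc1-c1ccc(F)cc1)N1CCN(c2cccc(Cl)c2)CC1`, is compound 3 with the same change as before: chloro in place of methoxy on an aromatic carbon. The place line of this change reads the same as for the earlier one, so it is the same change, not merely the same kind.

Because a 1.1-fold higher number from compound 2 to compound 1 (0.05 log units; within the scatter) lies within the scatter, the change is expected to move the number for compound 4 hardly at all from wherever compound 3 stands. Since compound 3 gave no number, the most likely outcome for compound 4 in this assay is expected to be a report of no activity again, and the estimated value, should one be measured, is 20000 nM with a range from 3000 nM to 100000 nM.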

Compound 4, half-maximal inhibitory concentration: "not active" (no number reported)
The entry for compound 4 holds no number; the estimate stays without a comparison.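

Compound 3 and compound 4 were both reported as not active in this assay, with no number for either, so no step can be read between them. The compounds shown leave open whether going from 3-methoxyphenyl to 3-chlorophenyl changes anything on the core of compound 3, and what separates that core from the core of compound 1. No supporting data bear on this result.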